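Does a Methoxy Group Make the Larger Compound Gentler?

A few compounds are considered here, and "the series" means these few. Any claim that something is new, unique, unknown or untested is made for them only; others in the source may bear on it.

Compound 1 `Cc1ccc2nc(NN)sc2c1` and compound 2 `COc1ccc2nc(NN)sc2c1` share one small core, while compound 3 `Cc1ccc2nc(Nn3c(-c4ccc([N+](=O)[O-])cc4)nnc3-c3cccnc3)sc2c1` and compound 4 `COc1ccc2nc(Nn3c(-c4ccc([N+](=O)[O-])cc4)nnc3-c3cccnc3)sc2c1` share a much larger one. The difference between the two cores is not broken down here.

In an ADME assay on MT4 cells (Homo sapiens) for cytotoxicity, read by MTT assay, with a stated time of 5 days (a lower number here means that less compound is tolerated, a higher number that more compound is tolerated), compound 1 gives 4.52 ug/mL, and compound 2 gives 14.8 ug/mL. Compound 2 differs from compound 1 by methoxy in place of methyl on an aromatic carbon, and that change brought a 3.3-fold higher number from compound 1 to compound 2 (0.52 log units; beyond the scatter), so more of compound 2 is tolerated. In this assay compound 3 gives 64.4 ug/mL, the highest of the three measured numbers. Compound 4 differs from compound 3 by methoxy in place of methyl on an aromatic carbon, the same change at the same kind of place on a different core.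

The expectation for compound 4 rests on a 3.3-fold higher number from compound 1 to compound 2 (0.52 log units; beyond the scatter). The two cores differ, so the step need not repeat exactly, and a somewhat smaller move in the same direction is expected, a 2.2-fold higher number from compound 3 to compound 4 (0.34 log units; beyond the scatter). In this assay compound 4 is therefore estimated at about 140 ug/mL, with a likely range from 60 ug/mL to 320 ug/mL.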

Compound 4, half-maximal cytotoxic concentration: 12.9 ug/mL
Compound 4: middle estimate off by 11-fold (1.04 log units), on the high side; the whole stated range lies above it.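

On the larger core in this assay, methoxy in place of methyl on an aromatic carbon brought a 5.0-fold lower number from compound 3 to compound 4 (0.70 log units; beyond the scatter) and thus less of the methoxy compound is tolerated, the opposite direction to the step on the small core. Set side by side, the two steps point opposite ways and lie further apart than repeated measurements would explain: the same change on two cores in this assay, a 3.3-fold higher number (0.52 log units; beyond the scatter) from compound 1 to compound 2 and a 5.0-fold lower number (0.70 log units; beyond the scatter) from compound 3 to compound 4, 16-fold (1.21 log units) apart, beyond the scatter of two such steps. This shows that, in this assay, the size and even the direction of this change did not carry from the core of compound 1 to the core of compound 3, but with a single pair on each core it does not show which part of the larger core matters, or what a third core would do.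

Still open, from the compounds shown here alone, is how other groups at this place, such as an amine, a hydroxyl or a longer chain like ethoxy, would behave on either core. Also open, going by these compounds, is whether the reversal would appear on a core carrying only part of the larger structure.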